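This account rests on a few compounds, and the source may have more. Where it says the series, first, only, none or still open, it means among the compounds named here.

Measured compounds:
- compound 1 `O=C1/C(=C/c2ccccc2)COc2ccc(Cl)cc21`: 331000 nM
- compound 2 `CC(=O)Nc1ccc(/C=C2\COc3ccccc3C2=O)cc1`: 1070000 nM
- compound 3 `COc1cccc(/C=C2\COc3ccccc3C2=O)c1OC`: 1910000 nM

In an assay on isolated protein for inhibition of Amine oxidase [flavin-containing] B (Homo sapiens) (on this read-out lower numbers stand for stronger inhibition and higher numbers for weaker inhibition), compound 3 gives the highest of the three numbers. For the measured compounds named here, its number sits within the scatter of the one for compound 2, so the two cannot be told apart, while it lies clearly higher than the one for compound 1, which is beyond the scatter. Compound 4 `COc1ccc(/C=C2\COc3ccccc3C2=O)c(OC)c1OC` differs from compound 3 by a single change: methoxy in place of hydrogen on an aromatic carbon. Going by the values given here, no pair of measured compounds here differs in exactly this way, so there is no directly comparable step to lean on. All three measured numbers are large and close together, and compound 4 keeps the shared core, so its number is expected to stay close to that of compound 3, a step of about a 1.0-fold higher number from compound 3 to compound 4 (0.02 log units; within the scatter), not beyond the scatter. For compound 4 in this assay the estimate is 2000000 nM, expected to fall between 700000 nM and 6000000 nM.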

Compound 4, half-maximal inhibitory concentration: 1320000 nM
Beside the measured number, compound 4's estimate is 1.5-fold (0.18 log units) above it, within the range that was stated.
By their numbers in this assay, from the lowest: compound 1; then compounds 2, 4 and 3 (each within the scatter of the next).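

In this assay, putting methoxy in place of hydrogen on this aromatic carbon, para to a large group and ortho to a methoxy group, gives a 1.4-fold lower number from compound 3 to compound 4 (0.16 log units; within the scatter) and leaves the two compounds indistinguishable. For the compounds shown here, this is the first single-place comparison in the set, and it shows that this position accepts the extra methoxy with no change that can be read beyond the scatter. No measurement shown here accounts for this result.

Going by these compounds, whether an amine, a carboxylic acid or a longer chain on this same carbon would shift the number remains open. So does whether methoxy here would have a similar effect on the chlorine-bearing core of compound 1.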